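From bromo to chloro on an aromatic carbon

The compounds below may be only part of what the source reports. "The series", "measured", "known", "first", "only" and "open" are said of these compounds alone.

- compound 1 (`O=c1nc2ccc(Br)cn2cc1Cc1ccc(Br)cc1`): 102000 nM
- compound 2 (`O=c1nc2ccccn2cc1Cc1ccc(F)cc1C(F)(F)F`): > 1000000 nM, a limit of the assay and not a number

Among the measured compounds shown here, in a functional assay on A549 cells (Homo sapiens) for cytotoxicity, read by MTT assay, with a stated time of 24 h (on this read-out lower numbers stand for stronger inhibition and higher numbers for weaker inhibition), compound 1 gives 102000 nM, the only true number available so far. Compound 2 is reported only as a limit, > 1000000 nM. For the measured compounds named here, no step between measured compounds has been determined, so the data offer no direct measure of the next change.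

Compound 3 (`O=c1nc2ccc(Br)cn2cc1Cc1ccc(Cl)cc1`) differs from compound 1 at one place: chloro in place of bromo on an aromatic carbon. It has chloro in place of bromo on an aromatic carbon, para to a large group, and the rest of the structure is the same. In this assay no change beyond the usual scatter is expected, and neither direction is favoured. The estimate is therefore anchored on compound 1 at 102000 nM. The expected change is a 1.1-fold higher number from compound 1 to compound 3 (0.05 log units; within the scatter). Compound 3 is expected at 115000 nM, with an estimated range of 50000 nM to 300000 nM.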

Compound 3, half-maximal inhibitory concentration: 105000 nM
Compound 3: middle estimate off by 1.1-fold (0.04 log units), on the high side; the range from low to high includes it.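

Among the compounds shown here, the step gives the first direct reading at this position: in this assay, chloro in place of bromo on an aromatic carbon, para to a large group, gives a 1.0-fold higher number from compound 1 to compound 3 (0.01 log units; within the scatter). For the compounds shown here, at this place on the core of compound 1, then, the two groups are not told apart by this read-out, something no earlier pair could show, as none offered a step in one place. Nothing given here bears on the cause of this result.

The compounds shown leave open whether a different group in the same place, such as fluoro, methoxy, an amine or a carboxylic acid, would shift the number beyond the usual scatter. They also leave open whether the bromo on the shared core could be exchanged for chloro with as little effect on the number.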